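A few compounds are considered here, and "the series" means these few. Any claim that something is new, unique, unknown or untested is made for them only; others in the source may bear on it.

Compound 1 `CC(O)(CSc1cccc(C(F)(F)F)c1)C(=O)Nc1ccc(S(F)(F)(F)(F)F)cc1` and compound 2 `CC(O)(CSc1cccc(OC(F)(F)F)c1)C(=O)Nc1ccc(S(F)(F)(F)(F)F)cc1` share one core and differ at a single aromatic carbon, where the change is trifluoromethoxy in place of trifluoromethyl on an aromatic carbon. In a functional assay on LNCaP cells (Homo sapiens) for antiproliferative activity, read by propidium iodide staining, with a stated time of 96 h (a lower number here means a stronger inhibitor, a higher number a weaker inhibitor), compound 1 gives 18300 nM, and compound 2 gives 12800 nM. This one change therefore produced a 1.4-fold lower number from compound 1 to compound 2 (0.16 log units; within the scatter), a step too small to count as a real difference between the two.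

Compound 3 `CC(O)(CSc1ccc(C(F)(F)F)cc1)C(=O)Nc1cccc(S(F)(F)(F)(F)F)c1` is built from the same atoms as compound 1, joined differently; the difference between the two cores is not broken down here. In this assay compound 3 gives 17500 nM, a number that lies within the scatter of the number for compound 1 and also within the scatter of the number for compound 2. So far, then, all three compounds sit in the same region, and none can be called stronger or weaker than another.

Compound 4 `CC(O)(CSc1ccc(OC(F)(F)F)cc1)C(=O)Nc1cccc(S(F)(F)(F)(F)F)c1` has not been measured yet. It stands to compound 3 as compound 2 stands to compound 1, through the same kind of change: trifluoromethoxy in place of trifluoromethyl on an aromatic carbon. The surroundings are not identical. In compound 2 the entering group sits meta to a large group, while in compound 4 it sits para to a large group. Among the measured compounds shown here, because the first instance of this change gave a 1.4-fold lower number from compound 1 to compound 2 (0.16 log units; within the scatter), the step for compound 4 in this assay is expected to be of similar small size, namely a 1.3-fold lower number from compound 3 to compound 4 (0.13 log units; within the scatter). On that basis compound 4 is estimated at 13000 nM, most likely between 6500 nM and 28000 nM.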

Compound 4, half-maximal inhibitory concentration: 10300 nM
The estimate for compound 4 lay 1.3-fold (0.10 log units) above the measured number, and the stated range covers the measured number.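

The same change on the core of compound 3 produces in this assay a 1.7-fold lower number from compound 3 to compound 4 (0.23 log units; within the scatter), again a step too small to count as a real difference between the two compounds. Set beside the first instance, the change behaves alike on the two cores, and the two small steps cannot be told apart: the same change on two cores in this assay, a 1.4-fold lower number (0.16 log units; within the scatter) from compound 1 to compound 2 and a 1.7-fold lower number (0.23 log units; within the scatter) from compound 3 to compound 4, 1.2-fold (0.07 log units) apart, within the scatter of two such steps. This shows that swapping trifluoromethyl for trifluoromethoxy stayed within the scatter on both cores, even with the group in different surroundings, but it does not show that the swap has any true effect on the number, or that a third core would behave the same way.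

The compounds shown carry only trifluoromethyl or trifluoromethoxy at this place, so it remains open what a quite different group there, such as an amine, a carboxylic acid or a longer chain, would do in this assay. Equally open, as far as these compounds go, is whether any change at this place can produce a step beyond the scatter.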